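The source may hold more compounds than are shown below. What is called first, only, known or untested is meant among the compounds shown, and "the series" means these compounds.

Series notes. The shared core of compound 1 `Cc1cccc(NC(=O)c2cccc(/C=C3\CC(=O)N(c4ccccc4)C3=O)c2)c1` carries a 3-methylphenyl on the amide-type nitrogen. In an ADME assay on SW480 cells (Homo sapiens) for cytotoxicity, read by MTT assay, with a stated time of 72 h (a lower number here means a stronger inhibitor, a higher number a weaker inhibitor), compound 1 gives > 100000 nM, which is a limit of the assay and not a measured number. Compound 2 `COc1cc(NC(=O)c2cccc(/C=C3\CC(=O)N(c4ccccc4)C3=O)c2)cc(OC)c1OC` carries the same core. In this assay compound 2 likewise reaches only > 100000 nM, again a limit rather than a number. Where compound 1 stands is therefore set only by the limit of > 100000 nM in this assay, at which 2 of the 2 values shown sit, and nothing in the data puts it either side of that limit.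

Compound 3 `O=C(Nc1ccc(Cl)cc1)c1cccc(/C=C2\CC(=O)N(c3ccccc3)C2=O)c1` is the next entry, not yet measured. It differs from compound 1 in one place: 4-chlorophenyl in place of 3-methylphenyl on an amide-type nitrogen. Among the measured compounds shown here, no step between measured compounds is recorded, so no measured change gives a size to expect. For the measured compounds named here, with both values so far sitting at the limit, the step from compound 1 to compound 3 is expected to be none beyond the scatter, a step that the limit leaves unreadable from compound 1 to compound 3. Compound 3 is estimated at 150000 nM, with a range from 40000 nM to 600000 nM, and a limit rather than a number is the more likely report.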

Compound 3, half-maximal inhibitory concentration: > 100000 nM
Compound 3: a limit, no number; the forecaster's own chance of this, stated with the estimate: 80%; the middle value does not contradict the limit.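

No step can be read from compound 1 to compound 3, as each gives only a limit of the assay and not a number: the limit of > 100000 nM in this assay, at which 3 of the 3 values shown sit.

The compounds shown leave open whether any group on the amide-type nitrogen gives a measured number in this assay, and how compound 1, compound 2 and compound 3 rank among themselves.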